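Swapping Chloro for Methyl at One Aromatic Carbon

The source may hold more compounds than are shown below. What is called first, only, known or untested is meant among the compounds shown, and "the series" means these compounds.

Of the compounds shown here, two built on a shared core have been measured in an ADME assay on the whole organism for pharmacokinetics, with Mus musculus as the target, at a dose of 10 mg/kg by the oral route; on this read-out lower numbers stand for lower exposure and higher numbers for higher exposure at the dose given. Compound 1, `CC/C(=C(/c1ccc(/C=C/C(=O)O)cc1)c1ccc2[nH]ccc2c1)c1ccccc1`, gives 9400 ng.h/mL. Compound 2, `CC/C(=C(/c1ccc(/C=C/C(=O)O)cc1)c1ccc2[nH]ncc2c1)c1ccccc1Cl`, gives 15000 ng.h/mL, the higher of the two numbers, although its gap to compound 1 is within the usual scatter, so the two readings cannot be told apart.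

Compound 3, `CC/C(=C(/c1ccc(/C=C/C(=O)O)cc1)c1ccc2[nH]ncc2c1)c1ccccc1C`, has not yet been measured. It differs from compound 2 in one place: methyl in place of chloro on an aromatic carbon. The place is an aromatic carbon of a six-membered aromatic ring of carbon only, ortho to a large group; taken one bond further out, the change reads 2-chlorophenyl to 2-methylphenyl.

Among the compounds with values here, no step between two measured compounds is available to guide the expectation, and the two measured values do not separate from each other. The expected step, a 1.3-fold lower number from compound 2 to compound 3 (0.10 log units; within the scatter), is therefore estimated to stay within the scatter, in either direction. Compound 3 is expected to give about 12000 ng.h/mL in this assay, with an estimated range from 5000 ng.h/mL to 30000 ng.h/mL.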

Compound 3, area under the concentration-time curve: 7200 ng.h/mL
Beside the measured number, compound 3's estimate is 1.7-fold (0.22 log units) above it, within the range that was stated.
By their numbers in this assay, from the lowest: compounds 3, 1 and 2 (each within the scatter of the next, the first and the last beyond it).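

In this assay, putting methyl in place of chloro on this aromatic carbon, ortho to a large group, gives a 2.1-fold lower number from compound 2 to compound 3 (0.32 log units; beyond the scatter) and provides the first reading of a single change among these compounds. The step is modest, but it shows that exposure at this dose can respond to what sits at this place on the ring, even when the change is small. By the counts alone, chloro and methyl look alike: each has one heavy atom, no ring, no hydrogen-bond donors or acceptors and no net charge, so those counts do not capture the difference seen here. Nothing available explains why the methyl compound gives the lower number.

With only chloro and methyl shown at this place, it remains open whether a fluorine, a methoxy group or an amine would give a number closer to that of compound 2 or compound 3. Going by these compounds, it is also open whether the same swap would give a similar step on a different core or in a second pharmacokinetic measure.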